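The source may report more compounds than this note shows. Statements on the series, on what has been measured and on what is new or still open speak of the compounds shown alone.

Compound 1, `C/C=C1/[C@H](O[C@@H]2O[C@H](CO)[C@@H](O)[C@H](O)[C@H]2O)OC=C(C(=O)OC)[C@H]1CC(=O)OCCC1CCCCC1`, is the anchor of this account. Within the data shown here, in a functional assay on SK-BR-3 cells (Homo sapiens) for antiproliferative activity, read by MTT assay, with a stated time of 72 h (a higher number here means a weaker inhibitor, a lower number a stronger inhibitor), compound 1 gives 2000 nM, and it stands alone in that respect: of the three values shown for this set, it is the only one reported as a number. The other two are limits of the assay. Compound 2, `C/C=C1/[C@H](O[C@@H]2O[C@H](COC(C)=O)[C@@H](OC(C)=O)[C@H](OC(C)=O)[C@H]2OC(C)=O)OC=C(C(=O)OC)[C@H]1CC(=O)SCCC`, is one of them. In this assay compound 2 gives only a limit, > 15000 nM. Compound 3, `C/C=C1/[C@H](O[C@@H]2O[C@H](COC(C)=O)[C@@H](OC(C)=O)[C@H](OC(C)=O)[C@H]2OC(C)=O)OC=C(C(=O)OC)[C@H]1CC(=O)OC`, is the other. In this assay compound 3 likewise gives only a limit, > 15000 nM. Among the measured compounds shown here, the single step between measured compounds, a step that the two limits leave unreadable from compound 2 to compound 3, therefore cannot be read, as both of its ends sit at the limit of > 15000 nM in this assay, at which 2 of the 3 values shown sit.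

The compound to be measured is compound 4, `C/C=C1/[C@H](O[C@@H]2O[C@H](CO)[C@@H](O)[C@H](O)[C@H]2O)OC=C(C(=O)OC)[C@H]1CC(=O)OCCCc1ccc(OC)c(OC)c1`. It differs from compound 1 at one place: 3,4-dimethoxybenzyl in place of cyclohexyl on a saturated chain carbon, two bonds along the chain from an oxygen next to a carbonyl group. No measured step touches this position, and the one step shown does not bear on it. With nothing to point to a change beyond the scatter, the step from compound 1 to compound 4 in this assay is expected to be small, a 1.1-fold lower number from compound 1 to compound 4 (0.05 log units; within the scatter). For compound 4 an estimated value of 1800 nM is expected, within a range from 500 nM to 6000 nM.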

Compound 4, half-maximal inhibitory concentration: > 20000 nM
Compound 4: a limit, no number; the forecaster's own chance of this, stated with the estimate: 10%; middle value at least 11-fold (1.04 log units) away from the limit.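

In this assay, among these compounds, the place on a saturated chain carbon, two bonds along the chain from an oxygen next to a carbonyl group, turns out to matter: 3,4-dimethoxybenzyl in place of cyclohexyl gives an at least 10-fold higher number from compound 1 to compound 4 (1.00 log units; beyond the scatter), which lies beyond the scatter and is the first readable step in this set. Among the compounds shown here, the one earlier step between measured compounds cannot be read and lies at a different place, and compound 2 and compound 3 each differ from compound 1 in more than one place, so none of them bore on this position. The result for compound 4 is a limit and not a number, so the step gives no exact size: the limit of > 20000 nM in this assay, at which 1 of the 4 values shown sits.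

The entering group brings an aromatic ring and two methoxy groups in one change, and the compounds shown do not separate the two. From the compounds shown here alone, how a plain phenyl or a 4-methoxyphenyl at this place would read remains open, as does whether a cycloalkyl ring other than cyclohexyl, such as cyclopentyl, would keep a value near that of compound 1.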